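Adding a cyano group to compound 2

This account rests on a few compounds, and the source may have more. Where it says the series, first, only, none or still open, it means among the compounds named here.

Three compounds have so far gone through an ADME assay for permeability, using PAMPA (a lower number here means that the compound crosses the layer more slowly, a higher number that the compound crosses the layer faster), and two of them returned a number. Compound 1 (`O=C(Nc1ccc([N+](=O)[O-])cc1Cl)c1cc(F)ccc1O`) has no result to offer ("not determined" (no result reported)) and gives no point of comparison. Compound 2 (`O=C(Nc1ccccc1Cl)c1cc(Cl)ccc1O`) reads 118 10^-6 cm/s and compound 3 (`CN1CCC(NC(=O)c2cc(Cl)ccc2O)CC1`) reads 212 10^-6 cm/s in the same measurement, so the two stand within the usual scatter of each other. Compound 2 therefore sits in a narrow field of one neighbour, and no order can be drawn between them.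

The next compound to be tested is compound 4 (`N#Cc1ccc(NC(=O)c2cc(Cl)ccc2O)c(Cl)c1`). It carries cyano in place of hydrogen on an aromatic carbon, at a place meta to a chloro group and para to a large group. Among the measured compounds shown here, no measured pair in this small set shows what such a change does, so the expectation starts from compound 2 at 118 10^-6 cm/s and remains loose. The estimated step of a 1.6-fold lower number from compound 2 to compound 4 (0.20 log units; within the scatter) is expected to point towards a lower number and to stay modest, close to the scatter. For compound 4 the expected reading in this assay is 75 10^-6 cm/s, with an estimated range from 28 10^-6 cm/s to 170 10^-6 cm/s for the measurement still to come.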

Compound 4, apparent permeability: 5.1 10^-6 cm/s
Compound 4: the middle estimate sits 15-fold (1.17 log units) above what was measured; the whole stated range lies above it.
By their numbers in this assay, from the lowest: compound 4; then compounds 2 and 3 (each within the scatter of the next).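

Among the compounds shown here, until now, the compounds offered no pair differing in one place, so nothing in this assay could be tied to a single change. Cyano in place of hydrogen on an aromatic carbon, meta to a chloro group and para to a large group, now gives a 23-fold lower number from compound 2 to compound 4 (1.36 log units; beyond the scatter) and this large step lies beyond the scatter, which shows that this place on the aromatic ring does not tolerate every change without consequence in this read-out, and that an addition of only 2 heavy atoms can be enough. No measurement at hand accounts for the size of the step.

With one group at one place, the compounds shown leave open whether the step belongs to cyano itself or would follow any group put there, and a methoxy group or an amine at the same carbon, or cyano on another carbon of the same ring, would separate these readings. From the compounds shown here alone, whether a step of this size would also appear on a core without the chloro group remains equally open.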